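A few compounds are considered here, and "the series" means these few. Any claim that something is new, unique, unknown or untested is made for them only; others in the source may bear on it.

In an ADME assay on HEK-293T cells (Homo sapiens) for cytotoxicity, read by MTT assay, with a stated time of 72 h (on this read-out lower numbers stand for stronger inhibition and higher numbers for weaker inhibition), compound 1 `O=C(Nc1nc2ccc(F)cc2s1)c1cn(-c2ccccc2)nc1-c1ccc(F)cc1` gives 16700 nM and compound 2 `O=C(Nc1nc2ccc(Cl)cc2s1)c1cn(-c2ccccc2)nc1-c1ccc(F)cc1` gives 45700 nM. Compound 3 `COc1ccc2nc(NC(=O)c3cn(-c4ccccc4)nc3-c3ccc(F)cc3)sc2c1` reaches only a limit of this assay, > 50000 nM. The step of a 2.7-fold higher number from compound 1 to compound 2 (0.44 log units; beyond the scatter) and the step of an at least 2.9-fold higher number from compound 1 to compound 3 (0.47 log units; beyond the scatter) both raise the number, while the step of an at least 1.0-fold higher number from compound 2 to compound 3 (0.03 log units; that floor lies within the scatter) stays within the scatter. Compound 3 thus stands at the weak end of the three values shown, with a limit rather than a number. Compound 4 `Cc1ccc2nc(NC(=O)c3cn(-c4ccccc4)nc3-c3ccc(F)cc3)sc2c1` differs from compound 3 by methyl in place of methoxy on an aromatic carbon. The two steps starting from compound 1 bear on this change, since swapping groups at this carbon moved the number only modestly, so a step of an at least 1.2-fold lower number from compound 3 to compound 4 (0.09 log units; that floor lies within the scatter) is expected, with no direction beyond the scatter. Compound 4 is therefore estimated at 40000 nM, between 15000 nM and 100000 nM.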

Compound 4, half-maximal inhibitory concentration: > 50000 nM
Compound 4 was reported as a limit; the forecaster's own chance of this, stated with the estimate: 45%; middle value at least 1.2-fold (0.09 log units) from the limit.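

In this assay compound 4 gives > 50000 nM, which is a limit and not a number. Methyl in place of fluoro gives an at least 2.9-fold higher number from compound 1 to compound 4 (0.47 log units; beyond the scatter), so methyl joins methoxy in giving a weaker result than fluoro at this carbon, while methyl in place of chloro gives an at least 1.0-fold higher number from compound 2 to compound 4 (0.03 log units; that floor lies within the scatter). The step between compound 3 and compound 4 cannot be read, because both stop at the same limit: the limit of > 50000 nM in this assay, at which 2 of the 4 values shown sit.

Going by these compounds, how far compound 3 and compound 4 lie past that limit stays open. Also open, on these data alone, is whether an amine or a carboxylic acid at this carbon would bring the number below that of compound 1.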